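Swapping trifluoromethyl for cyclobutyl on a phenoxy oxygen

The source may report more compounds than this note shows. Statements on the series, on what has been measured and on what is new or still open speak of the compounds shown alone.

Compound 1, with the structure `O=C(O)CCc1cc2cc(-c3cccc(OC(F)(F)F)c3)ccc2o1`, carries a propanoic acid chain on a shared core and a trifluoromethoxy group on its outer aromatic ring. Among the compounds with values here, in a functional assay on isolated protein for agonist activity at Free fatty acid receptor 1 (Homo sapiens), read by HTRF and inositol phosphate accumulation, with a stated time of 60 min (on this read-out lower numbers stand for an effect already at smaller amounts and higher numbers for an effect only at larger amounts of compound), compound 1 gives 1390 nM, the only plain number among the values gathered so far. Compound 2, `O=C(O)CCc1cc2cc(-c3cc(OC(F)(F)F)ccc3Cl)ccc2o1`, differs from compound 1 by chloro in place of hydrogen on an aromatic carbon. For compound 2 this assay reports only a limit, > 9950 nM. That gives an at least 7.1-fold higher number from compound 1 to compound 2 (0.85 log units; beyond the scatter), which rests on the limit of > 9950 nM in this assay, at which 1 of the 2 values shown sits, rather than on a measured number.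

Compound 3, `O=C(O)CCc1cc2cc(-c3cccc(OC4CCC4)c3)ccc2o1`, is a new variation on compound 1: cyclobutyl in place of trifluoromethyl on an oxygen on an aromatic ring. Within the data shown here, no measured step touches the group on that oxygen; the only step gathered, from compound 1 to compound 2, changes a different place and so does not bear directly on this exchange. With nothing pointing in either direction, compound 3 is expected to stay close to compound 1, a step of a 1.1-fold higher number from compound 1 to compound 3 (0.03 log units; within the scatter) within the scatter. Compound 3 is therefore estimated at 1500 nM, with a range from 400 nM to 6000 nM.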

Compound 3, half-maximal effective concentration: 2500 nM
The estimate for compound 3 lay 1.7-fold (0.22 log units) below the measured number, within the range that was stated.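

Within the data shown here, the step from trifluoromethyl to cyclobutyl is the first measured change of the group on this oxygen, and in this assay it reads a 1.8-fold higher number from compound 1 to compound 3 (0.25 log units; within the scatter). Both groups have the same count of heavy atoms, but one holds three fluorine atoms and the other a four-membered ring of carbon only, so for this pair the fluorine atoms are not needed to keep the read-out within the scatter of compound 1, and a ring can sit on this oxygen. Nothing measured among these compounds explains why such different groups read alike.

On these data alone, what stays open is how far this tolerance reaches: a much smaller group such as methyl, a longer chain, or a group carrying an amine or a carboxylic acid on the same oxygen could give quite a different number. As far as these compounds go, it is also open whether chloro in place of hydrogen on an aromatic carbon, the exchange that leads from compound 1 to compound 2, would act the same way on compound 3.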